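The source may report more compounds than this note shows. Statements on the series, on what has been measured and on what is new or still open speak of the compounds shown alone.

Compound 1 `CC(C)[C@H](NC(=O)COc1cccc2ccccc12)C(=O)N[C@@H](CC(=O)O)C(=O)CSC1=NCCS1` gives in a functional assay on Jurkat cells (Homo sapiens) for inhibition (a lower number here means a stronger inhibitor, a higher number a weaker inhibitor), only a limit, > 200000 nM.
Compound 2 `CC(C)[C@H](NC(=O)COc1cccc2ccccc12)C(=O)N[C@@H](CC(=O)O)C(=O)CSc1nnnn1C` gives in this assay only a limit, > 200000 nM.
Compound 3 `CC(C)[C@H](NC(=O)COc1cccc2ccccc12)C(=O)N[C@@H](CC(=O)O)C(=O)COc1nccc(C(F)(F)F)n1` gives in this assay only a limit, > 200000 nM.

Compound 3 thus stands nowhere that can be ranked: its value is a limit, and the two other values shown are limits as well, all sitting at the limit of > 200000 nM in this assay, at which 3 of the 3 values shown sit. Among the measured compounds shown here, the steps that bear on the change at hand are a step that the two limits leave unreadable from compound 1 to compound 3 and a step that the two limits leave unreadable from compound 2 to compound 3, and also a step that the two limits leave unreadable from compound 1 to compound 2; none of them has a readable size, since both ends of each sit at the limit.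

Compound 4 `CC(C)[C@H](NC(=O)COc1cccc2ccccc12)C(=O)N[C@@H](CC(=O)O)C(=O)COc1nccc2ccccc12` differs from compound 3 by isoquinolin-1-yl in place of 4-(trifluoromethyl)pyrimidin-2-yl on an oxygen on a saturated carbon. For the measured compounds named here, with no measured step of readable size, no direction can be derived for compound 4 in this assay, and the expectation rests only on the three limits. Compound 4 is therefore estimated at 150000 nM, with a range from 20000 nM to 600000 nM, most likely again reported as a limit. This amounts to an expected step of an at least 1.3-fold lower number from compound 3 to compound 4 (0.12 log units; that floor lies within the scatter).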

Compound 4, half-maximal inhibitory concentration: 106000 nM
For compound 4 the middle estimate is 1.4-fold (0.15 log units) above the measured one; measured number inside the range.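

With isoquinolin-1-yl on this oxygen, compound 4 is the only one of the compounds shown to give a number rather than a limit in this assay: the limit of > 200000 nM in this assay, at which 3 of the 4 values shown sit. Exchanging 4-(trifluoromethyl)pyrimidin-2-yl for this group gives an at least 1.8-fold lower number from compound 3 to compound 4 (0.27 log units; that floor lies within the scatter), and the broader changes at the same saturated chain carbon give an at least 1.8-fold lower number from compound 2 to compound 4 (0.27 log units; that floor lies within the scatter) and an at least 1.8-fold lower number from compound 1 to compound 4 (0.27 log units; that floor lies within the scatter). On these data alone, all three are floors set by the limits of the other compounds, so the true size of each remains unknown, and the steps among compound 1, compound 2 and compound 3 cannot be read.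

The compounds shown leave open how far the number would move with a phenyl or quinolin-2-yl group on this oxygen, or with an amine on the isoquinolin-1-yl group. They also leave open whether (isoquinolin-1-yl)sulfanyl would read the same as (isoquinolin-1-yl)oxy.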